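Ortho-substituted biaryl variants of a fatty acid receptor agonist

The compounds below may be only part of what the source reports. "The series", "measured", "known", "first", "only" and "open" are said of these compounds alone.

Measured compounds:
- compound 1, `CCc1ccccc1-c1cccc(COc2ccc([C@H](CC(=O)O)c3nccn3C)cc2)c1`: 48 nM
- compound 2, `Cc1c(Cl)cccc1-c1cccc(COc2ccc([C@H](CC(=O)O)c3nccn3C)cc2)c1`: 61 nM
- compound 3, `Cn1ccnc1[C@@H](CC(=O)O)c1ccc(OCc2cccc(-c3ccccc3Cl)c2)cc1`: 43 nM

All three share one core and differ only in the aromatic ring attached to it. In an assay on CHO cells for agonist activity at Free fatty acid receptor 1 (Homo sapiens), read by luminescence, with a stated time of 20 s, in the presence of a further agent that is not named here (on this read-out lower numbers stand for an effect already at smaller amounts and higher numbers for an effect only at larger amounts of compound), compound 1 gives 48 nM, compound 2 gives 61 nM and compound 3 gives 43 nM. Compound 3 stands within the scatter of both companions: a 1.1-fold lower number from compound 1 to compound 3 (0.05 log units; within the scatter) and a 1.4-fold lower number from compound 2 to compound 3 (0.15 log units; within the scatter), and a 1.3-fold higher number from compound 1 to compound 2 (0.10 log units; within the scatter) as well. Every change tried so far on this ring, whether a small alkyl or a halogen, has left the read-out essentially unchanged.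

Compound 4, `Cc1cccc(C)c1-c1cccc(COc2ccc([C@H](CC(=O)O)c3nccn3C)cc2)c1`, takes the next step in the same spirit: 2,6-dimethylphenyl in place of 2-chlorophenyl on an aromatic carbon. A second small group on that ring, and a methyl instead of a chlorine, are changes of the same kind as the three measured steps, none of which moved the number beyond the scatter. The expected step in this assay is therefore small, without a clear direction: an expected 1.2-fold higher number from compound 3 to compound 4 (0.07 log units; within the scatter). Compound 4 is estimated at 50 nM, with a likely range of 22 nM to 115 nM.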

Compound 4, half-maximal effective concentration: 58 nM
Compound 4: the middle estimate sits 1.2-fold (0.06 log units) below what was measured; low and high end bracket the measured number.
By their numbers in this assay, from the lowest: compounds 3, 1, 4 and 2 (each within the scatter of the next).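

In this assay, 2,6-dimethylphenyl reads the same as the earlier rings within the scatter, with a 1.3-fold higher number from compound 3 to compound 4 (0.13 log units; within the scatter) and a 1.1-fold lower number from compound 2 to compound 4 (0.02 log units; within the scatter) and also a 1.2-fold higher number from compound 1 to compound 4 (0.08 log units; within the scatter) in this small set. The earlier rings at this aromatic carbon carried a single group or, in compound 2, a methyl together with a chlorine; compound 4 adds a ring with two methyl groups and no chlorine, and the read-out still stays in the same narrow range.

Whether this position would stay as flat with an amine, a carboxylic acid or a longer chain such as butyl on the ring remains open, as all four rings shown carry only small alkyl groups or chlorine. Nothing given here explains why these four rings read alike.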